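Chain extension at the amide in two core variants

This account rests on a few compounds, and the source may have more. Where it says the series, first, only, none or still open, it means among the compounds named here.

Compound 1 `C=CC(=O)Nc1cc(Nc2nccc(-c3cn(C)c4ccc(F)cc34)n2)c(OC)cc1N(C)CCN(C)C` is the reference of this small set. In a functional assay on NCI-H1975 cells (Homo sapiens) for antiproliferative activity, read by MTT assay, with a stated time of 72 h (a lower number here means a stronger inhibitor, a higher number a weaker inhibitor), compound 1 gives 254 nM. Compound 2 `CC/C=C\C(=O)Nc1cc(Nc2nccc(-c3cn(C)c4ccc(F)cc34)n2)c(OC)cc1N(C)CCN(C)C` differs from it only at the carbonyl: but-1-en-1-yl in place of vinyl on a carbonyl carbon. Compound 2 gives 2600 nM, so the step is a 10-fold higher number from compound 1 to compound 2 (1.01 log units; beyond the scatter). Compound 3 `C=CC(=O)Nc1cc(Nc2nc(C)cc(-c3cn(C)c4ccc(F)cc34)n2)c(OC)cc1N(C)CCN(C)C` carries the other change: methyl in place of hydrogen on an aromatic carbon. Compound 3 gives 3830 nM, a step of a 15-fold higher number from compound 1 to compound 3 (1.18 log units; beyond the scatter). Compound 2 and compound 3 lie within the scatter of each other, so no order between them is claimed.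

Compound 4 `CC/C=C\C(=O)Nc1cc(Nc2nc(C)cc(-c3cn(C)c4ccc(F)cc34)n2)c(OC)cc1N(C)CCN(C)C` has not yet been measured. It combines both changes: relative to compound 3 it carries but-1-en-1-yl in place of vinyl on a carbonyl carbon, the same kind of change as from compound 1 to compound 2, and the place reads word for word the same in both pairs. The two cores differ by methyl in place of hydrogen on an aromatic carbon.

The expectation for compound 4 rests on a single measured instance of the change. Because the step of a 10-fold higher number from compound 1 to compound 2 (1.01 log units; beyond the scatter) was large, the step for compound 4 is expected at a 6.5-fold higher number from compound 3 to compound 4 (0.81 log units; beyond the scatter), close to the earlier one. Within the data shown here, the range is kept wide because compound 3 already gives 3830 nM and only one pair carries the change. Compound 4 is therefore estimated at 25000 nM in this assay. The expected span for compound 4 runs from 8000 nM to 80000 nM.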

Compound 4, half-maximal inhibitory concentration: 10400 nM
For compound 4 the middle estimate is 2.4-fold (0.38 log units) above the measured one, within the range that was stated.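

In this assay the change from vinyl to but-1-en-1-yl on the carbonyl carbon keeps its direction on the core of compound 3, with a 2.7-fold higher number from compound 3 to compound 4 (0.43 log units; beyond the scatter), but its size does not carry over: the same change on two cores in this assay, a 10-fold higher number (1.01 log units; beyond the scatter) from compound 1 to compound 2 and a 2.7-fold higher number (0.43 log units; beyond the scatter) from compound 3 to compound 4, 3.8-fold (0.58 log units) apart, beyond the scatter of two such steps

Read the other way, the methyl in place of hydrogen on an aromatic carbon also keeps its direction, with a 4.0-fold higher number from compound 2 to compound 4 (0.60 log units; beyond the scatter), and its size does not carry over either: the same change on two cores in this assay, a 15-fold higher number (1.18 log units; beyond the scatter) from compound 1 to compound 3 and a 4.0-fold higher number (0.60 log units; beyond the scatter) from compound 2 to compound 4, 3.8-fold (0.58 log units) apart, beyond the scatter of two such steps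

These two gaps are a single finding seen from the two sides of the same four compounds; it shows that direction carried over here while a step measured on one core did not give the size of the step on the other, but it does not show why, and one pair of cores sets no rule for the series.

The compounds shown leave open whether a longer chain on the carbonyl carbon, a saturated propyl chain or a chain ending in an amine would follow the same direction on both cores. They also leave open whether ethyl or chlorine in place of the methyl on the aromatic carbon would reduce the chain-extension step as the methyl does.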